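Removing the amino group from a nucleoside ester series

The source may report more compounds than this note shows. Statements on the series, on what has been measured and on what is new or still open speak of the compounds shown alone.

Compounds measured in an assay for inhibition of Maternal embryonic leucine zipper kinase (Homo sapiens), read by Z'-LYTE, with a stated time of 1 h, tested at 10 uM; on this read-out lower numbers stand for less inhibition and higher numbers for more inhibition at the one concentration tested (going by the name of the read-out):
compound 1, `Nc1ncnc2c1ncn2[C@@H]1O[C@H](COC(=O)c2cc[nH]c2)[C@@H](O)[C@H]1O`, gives 98%;
compound 2, `Nc1ncnc2c1ncn2[C@@H]1O[C@H](COC(=O)c2ccc[nH]2)[C@@H](O)[C@H]1O`, gives 95%;
compound 3, `Nc1nc2c(ncn2[C@@H]2O[C@H](COC(=O)c3cc[nH]c3)[C@@H](O)[C@H]2O)c(=O)[nH]1`, gives 87%.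

Compound 3 stands apart from compound 1 by a gap beyond the usual scatter, while its gap to compound 2 lies within it. Among the measured compounds shown here, the only step measured so far, a number 3 percentage points lower from compound 1 to compound 2 (within the scatter), concerns the pyrrole ester and not the base, so no measured step bears on the change studied here.

Compound 4, `O=C(OC[C@H]1O[C@@H](n2cnc3c(=O)[nH]cnc32)[C@H](O)[C@@H]1O)c1cc[nH]c1`, is compound 3 with hydrogen in place of amino on an aromatic carbon. With nothing in the data to anchor this change, a moderate loss is expected, a number 12 percentage points lower from compound 3 to compound 4 (beyond the scatter), and compound 4 is estimated to give 75% in this assay, with a range from 50% to 95%.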

Compound 4, a percentage reported as inhibition, at one concentration (the size of the read-out at that concentration, not a potency): 97%
Beside the measured number, compound 4's estimate is 22 percentage points below it; measured number outside the range, above it.
By their numbers in this assay, from the lowest: compounds 3, 2, 4 and 1 (each within the scatter of the next, the first and the last beyond it).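

In this assay, hydrogen in place of amino on the aromatic carbon between two ring nitrogen atoms gives a number 10 percentage points higher from compound 3 to compound 4 (within the scatter). At this position, then, the amino group can be removed without a change beyond the scatter, at the one concentration tested. Nothing available explains this result.

From the compounds shown here alone, whether a methyl group or a methoxy group on this carbon would give the same reading remains open. So does whether the same swap would hold with a 1H-pyrrol-2-yl ester in place of the 1H-pyrrol-3-yl ester.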